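This account rests on a few compounds, and the source may have more. Where it says the series, first, only, none or still open, it means among the compounds named here.

Measured so far:
- compound 1, `O=[N+]([O-])c1ccc2c(c1)CN(c1ncnc3c1ncn3[C@@H]1O[C@H](CO)[C@@H](O)[C@H]1O)CC2` — 5.5 nM
- compound 2, `CCCCCNc1ncnc2c1ncn2[C@@H]1O[C@H](CO)[C@@H](O)[C@H]1O` — 13500 nM
- compound 3, `Nc1ncnc2c1ncn2[C@@H]1O[C@H](COCCOCCNc2ncnc3c2ncn3[C@@H]2O[C@H](CO)[C@@H](O)[C@H]2O)[C@@H](O)[C@H]1O` — 912000 nM

Three compounds have numbers in an assay on isolated protein for binding affinity to Equilibrative nucleoside transporter 1 (Homo sapiens); on this read-out higher numbers stand for weaker inhibition and lower numbers for stronger inhibition. Compound 1 gives 5.5 nM, the lowest of the three. Compound 2 gives 13500 nM, the second highest number; its nearest neighbour is compound 3 at 912000 nM, a gap beyond the scatter, and its furthest is compound 1, far below it. Going by the values given here, no two of the measured compounds differ in one place only, so no single step has a measured size here; what can be said is that a bulkier, ring-bearing substituent on the shared core (compound 1) goes with a much lower number than the open pentyl chain of compound 2.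

Compound 4, `OC[C@H]1O[C@@H](n2cnc3c(NCc4ccco4)ncnc32)[C@H](O)[C@@H]1O`, is not yet measured. Relative to compound 2 the change is furan-2-yl in place of butyl on a saturated chain carbon bound to a nitrogen on an aromatic ring. The pentylamino group of compound 2 becomes a ((furan-2-yl)methyl)amino group; one acceptor enters with the ring.

Expectation in this assay: the direction is estimated downward, a step beyond the scatter but not approaching compound 1. For compound 4 the estimate is 1200 nM, within 150 nM to 9000 nM, which amounts to an expected step of an 11-fold lower number from compound 2 to compound 4 (1.05 log units; beyond the scatter).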

Compound 4, half-maximal inhibitory concentration: 36300 nM
Compound 4: the middle estimate sits 30-fold (1.48 log units) below what was measured; measured number above the stated range.
By their numbers in this assay, from the lowest: compound 1; then compound 2; then compound 4; then compound 3.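

In this assay, going by these compounds alone, the only single-place step available at this position, a 2.7-fold higher number from compound 2 to compound 4 (0.43 log units; beyond the scatter), is modest but beyond the scatter, and it runs upward: furan-2-yl in place of butyl on a saturated chain carbon bound to a nitrogen on an aromatic ring does not lower the number. The earlier impression that a ring-bearing substituent goes with a lower number therefore needs qualifying, since compound 4, at 36300 nM, carries a five-membered aromatic ring and goes against it. Nothing measured here gives a reason for the direction or size of this step.

Within the data shown here, compound 1, at 5.5 nM, differs from compound 2 and compound 4 in more than one place, as does compound 3, so no step involving either can be read and the low value of compound 1 cannot be tied to any single change. Still open, from the compounds shown here alone, is how a phenyl ring in place of the furan-2-yl ring would behave on the same nitrogen-bound carbon, and whether a longer chain between that nitrogen and the ring would shift the number in either direction.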